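Diaryl urea series: alkyne to propenyl linker

The compounds below may be only part of what the source reports. "The series", "measured", "known", "first", "only" and "open" are said of these compounds alone.

Measured so far:
compound 1 `CNC(=O)C#Cc1ccc(NC(=O)Nc2ccc(Cl)c(C(F)(F)F)c2)cc1`, 26400 nM
compound 2 `CC(NC(=O)c1cccc(-c2ccc(NC(=O)Nc3ccc(Cl)c(C(F)(F)F)c3)cc2)c1)c1ccccc1`, 5240 nM

In a functional assay on MX1 cells (Homo sapiens) for inhibition, read by MTT assay, with a stated time of 120 h (a higher number here means a weaker inhibitor, a lower number a stronger inhibitor), compound 1 gives 26400 nM, the highest of the two numbers. The nearest is compound 2, which gives 5240 nM, a gap beyond the usual scatter. Compound 3 `CNC(=O)/C(C)=C/c1ccc(NC(=O)Nc2ccc(Cl)c(C(F)(F)F)c2)cc1` has not been measured in this assay. It differs from compound 1 by 2-(methylcarbamoyl)prop-1-en-1-yl in place of 2-(methylcarbamoyl)ethynyl on an aromatic carbon. Within the data shown here, no step between measured compounds matches this change, so its direction is uncertain; a modest step from compound 1 to compound 3 of a 1.8-fold lower number from compound 1 to compound 3 (0.25 log units; within the scatter) toward a lower number is expected. Compound 3 is estimated at 15000 nM, with a range of 4000 nM to 50000 nM.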

Compound 3, half-maximal inhibitory concentration: > 50000 nM
Compound 3: no number, only a limit; the forecaster's own chance of this, stated with the estimate: 10%; middle value at least 3.3-fold (0.52 log units) away from the limit.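

In this assay, among these compounds, the replacement on an aromatic carbon, para to a large group, gives the first one-place step: an at least 1.8-fold higher number from compound 1 to compound 3 (0.27 log units; that floor lies within the scatter). Among the compounds shown here, compound 3 carries a limit rather than a number, so this step is only a floor: the limit of > 50000 nM in this assay, at which 1 of the 3 values shown sits. Unlike the earlier compounds, this pair shows that the 2-(methylcarbamoyl)prop-1-en-1-yl replacement gives no sign of lowering the number at this position.

The compounds shown do not separate the change from triple to double bond from the added methyl, which 2-(methylcarbamoyl)ethenyl would address. Going by these compounds, how a carboxylic acid or an amine would read at this position also remains open.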